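Nitro in Place of Trifluoromethyl on Compound 3

The compounds below may be only part of what the source reports. "The series", "measured", "known", "first", "only" and "open" are said of these compounds alone.

Three measured compounds share the core of compound 1 `COc1ccc(C(=O)c2cc(OC)c(OC)c(OC)c2)cc1N`. In a functional assay on DU-145 cells (Homo sapiens) for cytotoxicity, read by MTT assay, with a stated time of 72 h (on this read-out lower numbers stand for stronger inhibition and higher numbers for weaker inhibition), compound 1 gives 2100 nM. Compound 2 `COc1cccc(/C=C/C(=O)Nc2cc(C(=O)c3cc(OC)c(OC)c(OC)c3)ccc2OC)c1` gives 6200 nM in this assay, and compound 3 `COc1ccc(C(=O)c2cc(OC)c(OC)c(OC)c2)cc1NC(=O)/C=C/c1ccc(C(F)(F)F)cc1` gives 4300 nM. Compound 3 thus holds the second highest of the three numbers: compound 2 is its nearest neighbour, the two lying within the scatter of each other, while compound 1 sits beyond the scatter at a lower number.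

Compound 4 `COc1ccc(C(=O)c2cc(OC)c(OC)c(OC)c2)cc1NC(=O)/C=C/c1ccc([N+](=O)[O-])cc1` differs from compound 3 by nitro in place of trifluoromethyl on an aromatic carbon. Among the measured compounds shown here, no measured step touches this exact position. For the measured compounds named here, the only single-place step available, a 1.4-fold lower number from compound 2 to compound 3 (0.16 log units; within the scatter), exchanged the whole aryl group at the far end of the same arm and stayed within the scatter, so a smaller exchange on that ring is expected to stay within the scatter as well, in no particular direction. In the expectation for compound 4 this means a 1.1-fold lower number from compound 3 to compound 4 (0.03 log units; within the scatter). Compound 4 is therefore estimated at about 4000 nM, with a range from 1500 nM to 11000 nM.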

Compound 4, half-maximal inhibitory concentration: 15600 nM
The estimate for compound 4 lay 3.9-fold (0.59 log units) below the measured number; the whole stated range lies below it.
By their numbers in this assay, from the lowest: compound 1; then compounds 3 and 2 (each within the scatter of the next); then compound 4.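

In this assay, the aromatic carbon para to a large group proves sensitive to which group it carries: nitro in place of trifluoromethyl gives a 3.6-fold higher number from compound 3 to compound 4 (0.56 log units; beyond the scatter), a modest step but one beyond the scatter. The exchange of 3-methoxyphenyl for 4-nitrophenyl gives a 2.5-fold higher number from compound 2 to compound 4 (0.40 log units; beyond the scatter), also modest and beyond the scatter, whereas the exchange of 3-methoxyphenyl for 4-(trifluoromethyl)phenyl, a 1.4-fold lower number from compound 2 to compound 3 (0.16 log units; within the scatter), stayed within it. The earlier compounds shown here therefore gave no sign that the aryl group on this arm could move the number beyond the scatter, and here the outcome depends on the group that enters, with nitro standing apart from trifluoromethyl.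

Nothing available explains this rise. Going by these compounds, it remains open whether an amine or a carboxylic acid on the same carbon would stay with trifluoromethyl or move with nitro.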